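The source may hold more compounds than are shown below. What is called first, only, known or untested is meant among the compounds shown, and "the series" means these compounds.

Three compounds built on the shared core were tested in a functional assay on NPC-TW01 cells (Homo sapiens) for inhibition, read by MTT assay, with a stated time of 72 h; on this read-out higher numbers stand for weaker inhibition of growth and lower numbers for stronger inhibition of growth. Compound 1 `COC(=O)c1nc(C)n(-c2cccc(Br)c2)n1` gave only a limit of the assay rather than a number, namely > 100000 nM. Compound 2 `COC(=O)c1nc(C)n(-c2ccc(C(F)(F)F)cc2)n1` likewise stopped at the limit > 100000 nM. Compound 3 `CCCCc1nc(C(=O)OC)nn1-c1ccc(F)cc1`, which carries a butyl chain on the core, also returned only the limit > 100000 nM. Going by the values given here, compound 3 therefore stands nowhere in particular among the three: every value is a limit, so no compound can be placed above or below another, and no step between measured compounds can be drawn. The common ceiling is the limit of > 100000 nM in this assay, at which 3 of the 3 values shown sit. Compound 4 `COC(=O)c1nc(-c2ccsc2)n(-c2ccc(F)cc2)n1` has not yet been tested in this assay. It differs from compound 3 by one swap (thiophen-3-yl in place of butyl on an aromatic carbon), that is, thiophen-3-yl in place of butyl on an aromatic carbon. Among the compounds with values here, with no measured step to lean on, there is no ground for expecting this change to shift growth inhibition beyond the scatter in either direction. The step from compound 3 to compound 4 is estimated as a step that the limit leaves unreadable from compound 3 to compound 4, in effect none. Compound 4 is expected to give about 150000 nM in this assay, within a range from 40000 nM to 500000 nM, and most probably once more only a limit.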

Compound 4, concentration for 50% growth inhibition: 10700 nM
Compound 4: the middle estimate sits 14-fold (1.15 log units) above what was measured; the whole stated range lies above it.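

This position on an aromatic carbon, between two ring nitrogen atoms, clearly affects growth inhibition: putting thiophen-3-yl in place of butyl gives an at least 9.3-fold lower number from compound 3 to compound 4 (0.97 log units; beyond the scatter) in this assay. Compound 4, at 10700 nM, is the first compound shown to give a real number, so the series can now show measurable growth inhibition. From the compounds shown here alone, the true size of the step remains unknown, as the figure for it is only a minimum set by a limit, and the other three values are also limits: the limit of > 100000 nM in this assay, at which 3 of the 4 values shown sit.

The compounds shown do not reveal which feature of thiophen-3-yl matters, whether the aromatic ring as such, its sulfur atom or the way the ring is attached, and a phenyl or thiophen-2-yl group at the same place would help to separate these possibilities. Going by these compounds, it also remains open whether the methoxycarbonyl group is needed for this growth inhibition, a question that a carboxylic acid or an amide in its place on compound 4 could answer.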